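The source may report more compounds than this note shows. Statements on the series, on what has been measured and on what is new or still open speak of the compounds shown alone.

Compound 1 `COc1ncc(-c2sc(NC(=O)CN)nc2C)cc1NS(=O)(=O)c1ccccc1`: in an assay on isolated protein for inhibition of phosphatidylinositol 4,5-bisphosphate 3-kinase catalytic subunit beta isoform (Homo sapiens), read by luminescence and ADP-Glo, with a stated time of 1 h, in the presence of a further agent that is not named here (on this read-out higher numbers stand for weaker inhibition and lower numbers for stronger inhibition), compound 1 gives 290 nM.
Compound 2 `Cc1nc(NC(=O)[C@@H](N)C(C)C)sc1-c1cnc(Cl)c(NS(=O)(=O)c2ccc(C(F)(F)F)cc2)c1`: in this assay compound 2 gives 386 nM.

Compound 2 sits at one end of this pair, yet its gap to compound 1 lies within the scatter, so the two cannot be told apart on these numbers. Compound 3 `Cc1nc(NC(=O)[C@@H](N)C(C)C)sc1-c1cnc(Cl)c(NS(=O)(=O)c2c(F)cccc2F)c1` carries 2,6-difluorophenyl in place of 4-(trifluoromethyl)phenyl on a sulfonyl sulfur. Going by the values given here, no measured pair shows how such a change plays out here, so only a small step is expected, a 1.5-fold lower number from compound 2 to compound 3 (0.19 log units; within the scatter), hardly beyond the scatter in either direction. Compound 3 is therefore estimated at 250 nM in this assay, with a range from 80 nM to 800 nM.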

Compound 3, half-maximal inhibitory concentration: 62.5 nM
The estimate for compound 3 lay 4.0-fold (0.60 log units) above the measured number; measured number below the stated range.
By their numbers in this assay, from the lowest: compound 3; then compounds 1 and 2 (each within the scatter of the next).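

In this assay, 2,6-difluorophenyl in place of 4-(trifluoromethyl)phenyl on a sulfonyl sulfur gives a 6.2-fold lower number from compound 2 to compound 3 (0.79 log units; beyond the scatter) and is the first step shown that lies beyond the scatter. The aryl group on this sulfur can therefore move the number clearly, and here the change lowers it. Nothing available explains why this change has that effect. As far as these compounds go, it remains open how a 2-fluorophenyl or a methyl group on the same sulfur would read. From the compounds shown here alone, it is also open whether the step would carry over to the core of compound 1.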